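This account rests on a few compounds, and the source may have more. Where it says the series, first, only, none or still open, it means among the compounds named here.

Measured in a functional assay on G-361 cells (Homo sapiens) for cytotoxicity, read by MTT assay, with a stated time of 3 days; a higher number here means a weaker inhibitor, a lower number a stronger inhibitor:
- compound 1 `N#Cc1c(Cl)nc(SCc2nc3ccccc3[nH]2)nc1-c1ccccc1`: 12.5 nM
- compound 2 `N#Cc1c(NC(N)=O)nc(SCc2nc3ccccc3[nH]2)nc1-c1ccccc1`: 2.55 nM

Compound 2 has the lower of these two numbers. Compound 3 `N#Cc1c(-c2ccccc2)nc(SCc2nc3ccccc3[nH]2)nc1N1CCNCC1` has piperazin-1-yl in place of ureido on an aromatic carbon. Among the compounds with values here, the only measured step bearing on this change is a 4.9-fold lower number from compound 1 to compound 2 (0.69 log units; beyond the scatter), a modest gain on bringing in ureido in place of chloro. Within the data shown here, no measurement yet shows what piperazin-1-yl does, so losing ureido is expected to give back a similar modest amount, with wide uncertainty. The expected change is a 2.4-fold higher number from compound 2 to compound 3 (0.37 log units; beyond the scatter). For compound 3 the estimated value is 6 nM, within a range from 1.2 nM to 30 nM.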

Compound 3, half-maximal inhibitory concentration: 2.5 nM
The estimate for compound 3 lay 2.4-fold (0.38 log units) above the measured number; the range from low to high includes it.
By their numbers in this assay, from the lowest: compounds 3 and 2 (each within the scatter of the next); then compound 1.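

At this position, the one ortho to the cyano group, the change from ureido to the larger, ring-bearing piperazin-1-yl leaves the number in this assay within the scatter, with a 1.0-fold lower number from compound 2 to compound 3 (0.01 log units; within the scatter). The gain over chloro therefore does not depend on ureido alone: piperazin-1-yl also shows a 5.0-fold lower number from compound 1 to compound 3 (0.70 log units; beyond the scatter). Nothing available explains how two such different groups give such close numbers. On these data alone, it remains open whether a small amine such as dimethylamino would do the same. Morpholin-4-yl or 4-methylpiperazin-1-yl would test whether the free ring nitrogen of piperazin-1-yl matters.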